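The source may hold more compounds than are shown below. What is called first, only, known or untested is meant among the compounds shown, and "the series" means these compounds.

Compound 3 `CSc1ccc2c(c1)c(O)c(C(=O)N(C)C1CCCCC1)c(=O)n2C` stands second of the three numbers measured in a functional assay on the whole organism for inhibition, with Mus musculus as the target, at a dose of 32 mg/kg by the oral route; a higher number here means more inhibition at the dose given (going by the name of the read-out), a lower number less inhibition: compound 3 gives 43%, compound 1 `CSc1ccc2c(c1)c(O)c(S(=O)(=O)N(C)c1ccccc1)c(=O)n2C` gives 53%, and compound 2 `CSc1ccc2c(c1)c(O)c(C(=O)Nc1ccccc1)c(=O)n2C` gives 24%. Compound 3 and compound 1 lie within the scatter of each other, and compound 3 stands beyond the scatter above compound 2. Compound 4 `CSc1ccc2c(c1)c(O)c(C(=O)N(C)c1ccc(F)cc1)c(=O)n2C` is not yet measured; it differs from compound 3 by 4-fluorophenyl in place of cyclohexyl on an amide-type nitrogen. Among the compounds with values here, the one measured step that bears on this is a number 19 percentage points higher from compound 2 to compound 3 (beyond the scatter), where an aromatic ring on the amide gave way to a saturated one; compound 4 brings an aromatic ring back onto the amide-type nitrogen. A modest fall is therefore expected, a number 9 percentage points lower from compound 3 to compound 4 (within the scatter). Compound 4 is estimated at 34%, within a range from 15% to 55%.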

Compound 4, a percentage reported as inhibition, in the whole organism at one dose (the size of the read-out at that dose, not a potency): 100%
The estimate for compound 4 lay 66 percentage points below the measured number, and the stated range ends below it.
By their numbers in this assay, from the lowest: compound 2; then compounds 3 and 1 (each within the scatter of the next); then compound 4.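

In this assay, replacing cyclohexyl with 4-fluorophenyl on the amide-type nitrogen gives a number 57 percentage points higher from compound 3 to compound 4 (beyond the scatter), so the number responds strongly to this group, and an aromatic ring at this place can go with a high number. The earlier step, a number 19 percentage points higher from compound 2 to compound 3 (beyond the scatter), cannot be read as a penalty for aromatic rings alone, since that step also brought the methyl onto the nitrogen. Nothing given here accounts for the rise. From the compounds shown here alone, it remains open whether the ring or its fluorine carries the rise, which a plain phenyl, or a chlorine in place of the fluorine, on this methylated nitrogen would separate.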